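The compounds below may be only part of what the source reports. "The series", "measured", "known", "first", "only" and "open" are said of these compounds alone.

Measured compounds:
compound 1, `C=CCc1c(O)cc(O)c2c1OC(c1ccc(O)cc1)CC2=O` — 9.86% in a functional assay on aorta (Rattus norvegicus, strain Sprague-Dawley) for inhibition, with a stated time of 20 min; a higher number here means a larger maximal response, a lower number a smaller maximal response
compound 2, `C=CCc1c(O)ccc2c1OC(c1ccc(O)cc1)CC2=O` — 87.2% in this assay

Going by the values given here, of the two numbers in this assay, compound 2 stands highest; its nearest neighbour is compound 1, and the only measured step, a number 77.3 percentage points higher from compound 1 to compound 2 (beyond the scatter), is large and well beyond the scatter. That step is a hydrogen in place of hydroxy on an aromatic carbon of the shared core.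

Compound 3, `C=CCc1c(O)ccc2c1OC(c1ccc(O)c(OC)c1)CC2=O`, differs from compound 2 by methoxy in place of hydrogen on an aromatic carbon. Among the compounds with values here, no measured step bears on a change of this kind: the one step at hand concerns the loss of a hydroxy on the core, not the entry of a methoxy on the ring that carries the hydroxy group. Hence the measured data give no direction for this change, and compound 2 already shows a large maximal response.

The expectation is therefore a step of a number 7.2 percentage points lower from compound 2 to compound 3 (within the scatter) in this assay, which is within the scatter. Compound 3 is expected to give about 80%, estimated between 55% and 95%.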

Compound 3, largest response reached (Emax), in percent of the reference or control that the assay uses: 85%
Beside the measured number, compound 3's estimate is 5 percentage points below it; the range from low to high includes it.
By their numbers in this assay, from the lowest: compound 1; then compounds 3 and 2 (each within the scatter of the next).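

In this assay, methoxy in place of hydrogen on an aromatic carbon, ortho to a hydroxy group and meta to a large group, gives a number 2.2 percentage points lower from compound 2 to compound 3 (within the scatter), so this place on the six-membered aromatic ring of carbon only takes the added group without a readable change in maximal response. The earlier pair spoke only to a hydroxy on the shared core, where a number 77.3 percentage points higher from compound 1 to compound 2 (beyond the scatter) is large, and the new step shows that a change elsewhere in the molecule need not move the number in the same way. No measured property of these compounds bears on this result.

On these data alone, whether the result holds for other groups at this place remains open, since a single methoxy says nothing about a benzyloxy group, an amine or a carboxylic acid there. As far as these compounds go, it is also open whether methoxy at this place would read the same with the extra core hydroxy present, as in compound 1, which gives 9.86% in this assay.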